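Swapping bromo for acetyl on a shared imidazoline core

The source may hold more compounds than are shown below. What is called first, only, known or untested is meant among the compounds shown, and "the series" means these compounds.

Of the compounds shown here, three with a shared core have been measured in an assay on CHO cells with Alpha-2B adrenergic receptor (Homo sapiens) as the target; a higher number here means a larger maximal response, a lower number a smaller maximal response. Compound 1 `CC(C)Oc1ccccc1OC(C)C1=NCCN1` gives 0.5. Compound 2 `C=C(C)c1ccccc1OC(C)C1=NCCN1` gives 0.4, and compound 3 `CC(Oc1ccccc1Br)C1=NCCN1` gives 0.4. The steps between them are all small: a number 0.10 lower from compound 1 to compound 2 (within the scatter), a number 0.10 lower from compound 1 to compound 3 (within the scatter), and no change at the digits printed from compound 2 to compound 3 (within the scatter). Compound 3 thus sits level with compound 2 at the digits shown, the two together being the lowest of the three numbers, with compound 1 only a little higher and still within the scatter.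

The next compound, compound 4 `CC(=O)c1ccccc1OC(C)C1=NCCN1`, differs from compound 3 in one place: acetyl in place of bromo on an aromatic carbon. For the measured compounds named here, none of the measured steps involves acetyl, so no step bears directly on this change. What the measured steps do show is that replacing the group at this position, whether with isopropoxy, 1-methylethenyl or bromo, moved the response by no more than the scatter. On that basis a change no larger than the scatter is expected here too, with no direction favoured: the expected step is no change at the digits printed from compound 3 to compound 4 (within the scatter). Compound 4 is therefore estimated at 0.4, with a range from 0.2 to 0.6.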

Compound 4, intrinsic activity: the largest response reached, as a fraction of the reference agonist's: 0.6
Beside the measured number, compound 4's estimate is 0.20 below it; low and high end bracket the measured number.
By their numbers in this assay, from the lowest: compounds 2, 3, 1 and 4 (each within the scatter of the next, the first and the last beyond it).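

In this assay, for the compounds shown here, the group on this aromatic carbon turns out to be able to shift the maximal response beyond the scatter, which no earlier pair showed. Replacing bromo with acetyl gives a number 0.20 higher from compound 3 to compound 4 (beyond the scatter) and replacing 1-methylethenyl with acetyl gives a number 0.20 higher from compound 2 to compound 4 (beyond the scatter) as two modest steps, while replacing isopropoxy with acetyl gives a number 0.10 higher from compound 1 to compound 4 (within the scatter) and so does not separate those two compounds. Acetyl therefore stands apart from bromo and 1-methylethenyl but not from isopropoxy, and although it brings a carbonyl and a hydrogen-bond acceptor that bromo lacks, nothing available explains the result.

With only four groups shown on this aromatic carbon, it remains open whether an amine or a carboxylic acid there would match acetyl or fall level with bromo. On these data alone, it is also open whether the carbonyl itself goes with the higher number, which a longer chain ending in a carbonyl, or an ethyl group in place of acetyl, could help to test.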